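Fluoro for chloro, ortho to a large group

The source may report more compounds than this note shows. Statements on the series, on what has been measured and on what is new or still open speak of the compounds shown alone.

Compound 1 `Cc1ccc(-c2cc(N3CCC(CNS(N)(=O)=O)CC3)ncn2)cc1` gives 33900 nM in a functional assay on HT-29 cells (Homo sapiens) for antiproliferative activity, read by sulforhodamine B assay, with a stated time of 48 h; a higher number here means a weaker inhibitor of growth, a lower number a stronger inhibitor of growth. Compound 2 `NS(=O)(=O)NCC1CCN(c2cc(-c3cccc(Cl)c3)ncn2)CC1` gives 47500 nM in this assay, and a 1.4-fold higher number from compound 1 to compound 2 (0.15 log units; within the scatter). For compound 3 `NS(=O)(=O)NCC1CCN(c2cc(-c3ccccc3Cl)ncn2)CC1` the reading in this assay is a limit of the assay, > 100000 nM. Compound 3 thus sits at the weak end of the numbers shown, with both steps into it pointing the same way: an at least 2.9-fold higher number from compound 1 to compound 3 (0.46 log units; beyond the scatter) and an at least 2.1-fold higher number from compound 2 to compound 3 (0.32 log units; beyond the scatter). Compound 4 `NS(=O)(=O)NCC1CCN(c2cc(-c3ccccc3F)ncn2)CC1` carries fluoro in place of chloro on an aromatic carbon. Going by the values given here, no measured step bears directly on a halogen exchange at this place; the two steps reaching compound 3 show only weaker growth inhibition for the 2-chlorophenyl group. Compound 4 is therefore expected to move little, a number no higher from compound 3 to compound 4 (the limit leaves the size open), staying near the limit. The estimate for compound 4 in this assay is 100000 nM, between 40000 nM and 300000 nM.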

Compound 4, concentration for 50% growth inhibition: 80400 nM
Compound 4: the middle estimate sits 1.2-fold (0.09 log units) above what was measured; the measured number falls inside the stated range.
By their numbers in this assay, from the lowest: compounds 1, 2 and 4 (each within the scatter of the next, the first and the last beyond it). At a limit, above all of these: compound 3.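

With fluoro in place of chloro, a group at this place, ortho to a large group, gives a readable number in this assay: an at least 1.2-fold lower number from compound 3 to compound 4 (0.09 log units; that floor lies within the scatter). From the compounds shown here alone, compound 3 remains at a limit of the assay, so the true size of this exchange is unknown: the limit of > 100000 nM in this assay, at which 1 of the 4 values shown sits. Among the readable numbers, the 2-fluorophenyl group is separated only from 4-methylphenyl: a 2.4-fold higher number from compound 1 to compound 4 (0.38 log units; beyond the scatter), whereas a 1.7-fold higher number from compound 2 to compound 4 (0.23 log units; within the scatter).

Going by these compounds, whether a methoxy group or an amine at this place would give a lower number remains open. So does the effect of fluoro at the other positions of the phenyl ring.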